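This account rests on a few compounds, and the source may have more. Where it says the series, first, only, none or still open, it means among the compounds named here.

Measured compounds:
compound 1 `COc1cc(-c2nn(-c3cccc(NC(=O)Nc4ccc(Cl)c(C(F)(F)F)c4)c3)cc2-c2ccncc2)ccc1Cl`; in a functional assay on UACC-62 cells (Homo sapiens) for inhibition, read by sulforhodamine B assay, with a stated time of 48 h (a higher number here means a weaker inhibitor of growth, a lower number a stronger inhibitor of growth), compound 1 gives 737 nM
compound 2 `COc1cc(-c2nn(-c3cccc(NC(=O)c4ccccc4)c3)cc2-c2ccncc2)ccc1Cl`; in this assay compound 2 gives 692 nM

Among the compounds with values here, of these two numbers, the one for compound 1 is the higher, yet a 1.1-fold lower number from compound 1 to compound 2 (0.03 log units; within the scatter) lies within the scatter, so the two compounds cannot be separated. Compound 3 `O=C(Nc1cccc(-n2cc(-c3ccncc3)c(-c3ccc(Cl)c(O)c3)n2)c1)Nc1ccc(Cl)c(C(F)(F)F)c1` differs from compound 1 by hydrogen in place of methyl on an oxygen on an aromatic ring. Within the data shown here, the single measured step alters a different part of the molecule and so says nothing about this change; there is no ground for expecting a move beyond the scatter. The step expected is a 1.0-fold higher number from compound 1 to compound 3 (0.01 log units; within the scatter). Compound 3 is thus estimated at 750 nM, between 250 nM and 2300 nM.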

Compound 3, concentration for 50% growth inhibition: 627 nM
Compound 3: the middle estimate sits 1.2-fold (0.08 log units) above what was measured, and the stated range covers the measured number.
By their numbers in this assay, from the lowest: compounds 3, 2 and 1 (each within the scatter of the next).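

In this assay, hydroxy in place of methoxy on the aromatic ring gives a 1.2-fold lower number from compound 1 to compound 3 (0.07 log units; within the scatter) and so cannot be told from no change. This shows that the methyl on this oxygen can be removed from compound 1 without a move beyond the scatter, whereas the earlier step concerned only the group on the carbonyl carbon. Nothing available offers an explanation for this result.

Going by these compounds, whether a longer chain on this oxygen, or an amine in place of the hydroxy, would leave the number as little moved remains open. So does whether the same change would hold on compound 2.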